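Swapping the benzyl substituent on a thienopyran acid

The source may hold more compounds than are shown below. What is called first, only, known or untested is meant among the compounds shown, and "the series" means these compounds.

In a functional assay on CHO/Galpha16 cells for antagonist activity at prostaglandin E2 receptor EP4 subtype (Homo sapiens), read by calcium flux, with a stated time of 15 min (on this read-out higher numbers stand for weaker inhibition and lower numbers for stronger inhibition), compound 2 `COc1cccc(Cc2sc3c(c2C(=O)N[C@@H](C)c2ccc(C(=O)O)cc2)CCOC3)c1` gives 1.9 nM. Compound 1 `C[C@H](NC(=O)c1c(CCc2ccc(F)cc2)sc2c1CC(C)(C)OC2)c1ccc(C(=O)O)cc1` gives 36.2 nM in this assay, so compound 2 carries the lower of the two numbers, and the gap between them lies beyond the scatter. Compound 3 `COC(=O)c1ccc([C@H](C)NC(=O)c2c(Cc3ccc(F)cc3)sc3c2CCOC3)cc1` reaches only a limit of this assay, > 1000 nM, and no number. Compound 4 `CC(C)c1ccc(Cc2sc3c(c2C(=O)N[C@@H](C)c2ccc(C(=O)O)cc2)CCOC3)cc1` has not yet been measured; it differs from compound 2 in one place: 4-isopropylphenyl in place of 3-methoxyphenyl on a saturated chain carbon bound to an aromatic carbon. For the measured compounds named here, no measured pair shows this change, so the size of the step is open. The change is estimated to give a 2.6-fold higher number from compound 2 to compound 4 (0.42 log units; beyond the scatter), a step upward in number that may stay within the scatter. Compound 4 is expected at 5 nM, in a range from 1.5 nM to 25 nM.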

Compound 4, half-maximal inhibitory concentration: 2.7 nM
Estimate against measurement, compound 4: 1.9-fold (0.27 log units) above, and the stated range covers the measured number.
By their numbers in this assay, from the lowest: compounds 2 and 4 (each within the scatter of the next); then compound 1. At a limit, above all of these: compound 3.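

In this assay, the step at this place, on a saturated chain carbon bound to an aromatic carbon, reads a 1.4-fold higher number from compound 2 to compound 4 (0.15 log units; within the scatter). The 4-isopropylphenyl, with no hydrogen-bond acceptor, thus serves here as well as the 3-methoxyphenyl, with its one, so that acceptor is not needed for a number of this size. Nothing measured here explains this result.

The swap changes both the group and where it sits on the phenyl ring, so the two contributions cannot be told apart. Going by these compounds, whether an amine or a carboxylic acid would be accepted on that phenyl ring also stays open.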